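The source may hold more compounds than are shown below. What is called first, only, known or untested is meant among the compounds shown, and "the series" means these compounds.

Measured compounds:
- Compound 1, `Cc1ccc(S(=O)(=O)c2cnc3ccc(Cl)cc3c2N2CCC(C)CC2)cc1F`, gives 68% in an assay on isolated protein for displacement of a labelled ligand from metabotropic glutamate receptor 5 (Homo sapiens), with a stated time of 60 min, tested at 1 uM; on this read-out lower numbers stand for less inhibition and higher numbers for more inhibition at the one concentration tested (going by the name of the read-out).
- Compound 2, `COc1ccc(S(=O)(=O)c2cnc3ccc(C)cc3c2N2CCC(C)CC2)cc1`, gives 62% in this assay.
- Compound 3, `COc1ccc(S(=O)(=O)c2cnc3ccc(OC)cc3c2N2CCC(C)CC2)cc1`, gives 41% in this assay.

Compound 2 stands second highest of the three numbers. Its value and that of compound 1 lie within the usual scatter of each other, so they cannot be told apart. Compound 3 is the furthest away: the step of a number 21 percentage points lower from compound 2 to compound 3 (beyond the scatter) lies beyond the scatter.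

Compound 4, `COc1cccc(S(=O)(=O)c2cnc3ccc(C)cc3c2N2CCC(C)CC2)c1`, has not yet been measured in this assay. Its structure differs from compound 2 in one place: 3-methoxyphenyl in place of 4-methoxyphenyl on a sulfonyl sulfur. Both compounds carry the same set of atoms; only the point at which the methoxy group sits on the phenyl ring attached to the sulfonyl sulfur differs.

Among the measured compounds shown here, the one measured step, from compound 2 to compound 3, changes a group on the shared core rather than the phenyl ring on the sulfonyl sulfur, so it does not bear directly on this change. For the measured compounds named here, no measured pair shows what moving the methoxy group on that ring does. With nothing to point either way, a step of a number 4 percentage points lower from compound 2 to compound 4 (within the scatter) is expected, that is, none beyond the scatter. Compound 4 is therefore estimated at 58% in this assay, with a likely range from 40% to 75%.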

Compound 4, a percentage reported as inhibition, at one concentration (the size of the read-out at that concentration, not a potency): 96%
Beside the measured number, compound 4's estimate is 38 percentage points below it, and the stated range ends below it.
By their numbers in this assay, from the lowest: compound 3; then compounds 2 and 1 (each within the scatter of the next); then compound 4.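

Moving the methoxy group on the phenyl ring attached to the sulfonyl sulfur, with 3-methoxyphenyl in place of 4-methoxyphenyl, matters in this assay, giving a step of a number 34 percentage points higher from compound 2 to compound 4 (beyond the scatter) that is the first measured change on this ring. The leaving and entering groups have the same atoms and the same counts of hydrogen-bond donors and acceptors, so this read-out distinguishes where the methoxy group sits on the ring, not only which atoms the compound contains. No available evidence accounts for this difference.

Going by these compounds, because each compound was tested at only one concentration, these results give the size of inhibition at that concentration and not a potency, and it remains open whether the same move on the ring has a similar effect with the other groups carried by the shared core, such as the methoxy group of compound 3. On these data alone, it also remains open what would happen if the methoxy group on this ring were replaced by an ethoxy group, a hydroxyl group or an amine.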